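Working notes: replacing the 4-chloropiperidin-1-yl group

The compounds below may be only part of what the source reports. "The series", "measured", "known", "first", "only" and "open" are said of these compounds alone.

Values in an ADME assay (liver) for metabolic stability, with Liver microsome (Homo sapiens) as the target, using microsomes; a higher number here means that the compound lasts longer, a lower number that the compound disappears faster:
- Compound 1 `CCc1nc2cc(Cl)ccn2c1C(=O)NCc1ccc(-c2ccc(C(=O)O)cc2)cc1`, a limit: > 2 h
- Compound 2 `CCc1nc2cc(Cl)ccn2c1C(=O)NCc1ccc(-c2ccc[nH]2)cc1`, a limit: > 2 h
- Compound 3 `CCc1nc2cc(Cl)ccn2c1C(=O)NCc1ccc(N2CCC(Cl)CC2)cc1`: 0.183 h

Going by the values given here, compound 3 is the only compound here with a number, at 0.183 h. The other two compounds are reported only as limits. The next compound is compound 4 `CCc1nc2cc(Cl)ccn2c1C(=O)NCc1ccc(N2CC3CCCCC3C2)cc1`, and the change is a group of 9 heavy atoms (8 carbon, 1 nitrogen; one five-membered non-aromatic ring with 1 hetero atom, one six-membered non-aromatic ring of carbon only) in place of a group of 7 heavy atoms (5 carbon, 1 nitrogen, 1 chlorine; one six-membered non-aromatic ring with 1 hetero atom), on an aromatic carbon, on an aromatic carbon of a six-membered aromatic ring of carbon only, para to a large group.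

Among the compounds with values here, two measured steps bear on this place: an at least 10-fold lower number from compound 1 to compound 3 (1.03 log units; beyond the scatter) and an at least 10-fold lower number from compound 2 to compound 3 (1.03 log units; beyond the scatter). Both are large, so the group here can matter in this assay. Neither brings in the entering group, however, and both start from an aromatic group. Compound 4 keeps a non-aromatic ring with 1 hetero atom, as compound 3 does at 0.183 h, so no large step is expected. The expected step is a 1.2-fold lower number from compound 3 to compound 4 (0.09 log units; within the scatter), which would lie within the scatter. The estimate for compound 4 is 0.15 h, with an expected range of 0.06 h to 0.4 h.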

Compound 4, half-life: 0.248 h
The estimate for compound 4 lay 1.7-fold (0.22 log units) below the measured number, and the stated range covers the measured number.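

In this assay, a second non-aromatic group at this place gives a 1.4-fold higher number from compound 3 to compound 4 (0.13 log units; within the scatter), so exchanging 4-chloropiperidin-1-yl, and with it the chlorine, for the larger group with two non-aromatic rings does not move the number beyond the scatter. Across the four compounds, the two with a non-aromatic group at this place both sit well under the two with an aromatic group, with an at least 8.0-fold lower number from compound 2 to compound 4 (0.90 log units; beyond the scatter) and an at least 8.0-fold lower number from compound 1 to compound 4 (0.90 log units; beyond the scatter), both beyond the scatter. These two steps are bounds and not sizes, as each starts from a limit: the limit of > 2 h in this assay, at which 2 of the 4 values shown sit.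

The compounds shown do not separate the aromatic ring from the carboxylic acid or the ring hydrogen that the aromatic groups carry. A phenyl group without a carboxylic acid, or a piperidine carrying one, would address this; so far neither stands in the series.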